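Leaving the trihydroxyphenyl limit for a methylthiophene

The compounds below may be only part of what the source reports. "The series", "measured", "known", "first", "only" and "open" are said of these compounds alone.

Compound 1 `Cc1ccc(CS(=O)(=O)/C(=C/c2cccc(Cl)c2Cl)C(=O)c2ccc(Cl)cc2)cc1`: 1000 nM
Compound 2 `Cc1ccc(CS(=O)(=O)/C(=C/c2c(O)cc(O)cc2O)C(=O)c2ccc(Cl)cc2)cc1`: > 100000 nM
Compound 3 `Cc1ccc(CS(=O)(=O)/C(=C/c2ccc(C)s2)C(=O)c2ccc(Cl)cc2)cc1`: not yet measured

In a functional assay on DU-145 cells (Homo sapiens) for inhibition, read by trypan blue exclusion, with a stated time of 96 h (a lower number here means a stronger inhibitor of growth, a higher number a weaker inhibitor of growth), compound 2 stands at > 100000 nM, which is a limit of the assay and not a number. Compound 3 carries 5-methylthiophen-2-yl in place of 2,4,6-trihydroxyphenyl on a double-bonded chain carbon bound to a double-bonded chain carbon. For the measured compounds named here, one measured step bears on this change: an at least 100-fold higher number from compound 1 to compound 2 (2.00 log units; beyond the scatter), a large step beyond the scatter. With that same 2,4,6-trihydroxyphenyl gone, a large move to a lower number is expected, towards compound 1 at 1000 nM. The expected step is an at least 50-fold lower number from compound 2 to compound 3 (1.69 log units; beyond the scatter). For compound 3 the estimate is 2000 nM, with an expected range from 300 nM to 15000 nM.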

Compound 3, concentration for 50% growth inhibition: 25000 nM
Compound 3: the middle estimate sits 13-fold (1.10 log units) below what was measured, outside the stated range (above it).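

In this assay, the change away from the 2,4,6-trihydroxyphenyl group restores measurable growth inhibition, with an at least 4.0-fold lower number from compound 2 to compound 3 (0.60 log units; beyond the scatter). The recovery is only partial, however: 5-methylthiophen-2-yl does not match the 2,3-dichlorophenyl group of compound 1, with a 25-fold higher number from compound 1 to compound 3 (1.40 log units; beyond the scatter). Losing the trihydroxyphenyl group is therefore not enough on its own, and what replaces it on this carbon also matters.

On these data alone, the true size of the first step stays open, since compound 2 rests on a limit of the assay and not a number: the limit of > 100000 nM in this assay, at which 1 of the 3 values shown sits. Also open, as far as these compounds go, is how a thiophene carrying an amine or a carboxylic acid in place of the methyl group would behave.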